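This account rests on a few compounds, and the source may have more. Where it says the series, first, only, none or still open, it means among the compounds named here.

Compound 1 `C/C=C/C(=O)NCCOc1ccc(Oc2c(-c3ccc(F)cc3)sc3cc(O)ccc23)cc1`: in a functional assay on MCF7 cells (Homo sapiens) for antiproliferative activity, read by CCK-8 assay, with a stated time of 48 h (on this read-out higher numbers stand for weaker inhibition and lower numbers for stronger inhibition), compound 1 gives 21700 nM.
Compound 2 `CN(C)C(=O)/C=C/CNCCOc1ccc(Oc2c(-c3ccc(F)cc3)sc3cc(O)ccc23)cc1`: in this assay compound 2 gives 13800 nM.

Compound 2 holds the lowest of the two numbers, but its step to compound 1, a 1.6-fold lower number from compound 1 to compound 2 (0.20 log units; within the scatter), is within the scatter, so no order between them is claimed. Compound 3 `C=C(C)C(=O)N1CC(Oc2ccc(Oc3c(-c4ccc(F)cc4)sc4cc(O)ccc34)cc2)C1` differs from compound 2 by 1-((1-methylethenyl)carbonyl)azetidin-3-yl in place of 2-((3-(dimethylcarbamoyl)prop-2-en-1-yl)amino)ethyl on an oxygen on an aromatic ring. Among the measured compounds shown here, the only measured step concerns the group on the amine nitrogen, not this linker, and it was small; no step bears directly on the change to compound 3. Compound 3 is therefore expected to stay near compound 2, with an expected step of a 1.2-fold lower number from compound 2 to compound 3 (0.06 log units; within the scatter). The estimate for compound 3 in this assay is 12000 nM, range 3500 nM to 40000 nM.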

Compound 3, half-maximal inhibitory concentration: > 25000 nM
Compound 3: only a limit was reported; the forecaster's own chance of this, stated with the estimate: 10%; middle value at least 2.0-fold (0.31 log units) from the limit.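

In this assay, compound 3 gives only a limit, not a number: the limit of > 25000 nM in this assay, at which 1 of the 3 values shown sits.

For 1-((1-methylethenyl)carbonyl)azetidin-3-yl in place of the open chains on the oxygen on an aromatic ring, the steps read an at least 1.8-fold higher number from compound 2 to compound 3 (0.25 log units; that floor lies within the scatter) and an at least 1.1-fold higher number from compound 1 to compound 3 (0.06 log units; that floor lies within the scatter). Both floors lie within the scatter, so this first change at the oxygen shows no gain, while its true size and any order among the three compounds stay unsettled.

Still open, on these data alone, is whether the azetidine with a free amine on its nitrogen, or a longer chain on the oxygen, would give a number rather than a limit.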